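The compounds below may be only part of what the source reports. "The series", "measured", "known", "first", "only" and "open" are said of these compounds alone.

Measured so far:
- compound 1, `COc1ccc(C2=C(c3ccc(SC)cc3)CC3CCCN3C2=O)cc1O`: 5000 nM in a functional assay on U-251 cells (Homo sapiens) for cytotoxicity; on this read-out lower numbers stand for stronger inhibition of growth and higher numbers for weaker inhibition of growth
- compound 2, `CSc1ccc(C2=C(c3ccc(F)c(C)c3)C(=O)N3CCCC3C2)cc1`: 200 nM in this assay
- compound 3, `CSc1ccc(C2=C(c3ccc(OCC4CO4)cc3)C(=O)N3CCCC3C2)cc1`: 80 nM in this assay

Compound 1 has the highest number of the three in this assay, so the weakest inhibition of growth. Its nearest neighbour is compound 2, reached by a 25-fold lower number from compound 1 to compound 2 (1.40 log units; beyond the scatter). Among the compounds with values here, compound 3 lies further away: compound 3 gives 80 nM, well below compound 1, though no single-point step links the two.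

Compound 4, `CSc1ccc(C2=C(c3ccc(Br)cc3)C(=O)N3CCCC3C2)cc1`, is not yet measured. It differs from compound 1 in one place: 4-bromophenyl in place of 3-hydroxy-4-methoxyphenyl on a double-bonded ring carbon. Within the data shown here, the one measured step that bears on this change is the same exchange at the same position on the shared core, with a different entering aryl group: a 25-fold lower number from compound 1 to compound 2 (1.40 log units; beyond the scatter). There the 3-hydroxy-4-methoxyphenyl, with 1 hydrogen-bond donor and 2 hydrogen-bond acceptors, gave way to a phenyl carrying only small substituents, and the number fell by a large margin. The 4-bromophenyl entering in compound 4 likewise brings 0 hydrogen-bond donors and 0 hydrogen-bond acceptors. Among the measured compounds shown here, a step of comparable size and the same direction is therefore expected, a 20-fold lower number from compound 1 to compound 4 (1.30 log units; beyond the scatter), with the range wide because only one precedent is available. Compound 4 is estimated at 250 nM, between 80 nM and 800 nM.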

Compound 4, concentration for 50% growth inhibition: 7000 nM
Beside the measured number, compound 4's estimate is 28-fold (1.45 log units) below it; measured number above the stated range.
By their numbers in this assay, from the lowest: compound 3; then compound 2; then compounds 1 and 4 (each within the scatter of the next).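

Replacing 3-hydroxy-4-methoxyphenyl with 4-bromophenyl on the double-bonded ring carbon leaves this assay essentially unchanged, with a 1.4-fold higher number from compound 1 to compound 4 (0.15 log units; within the scatter), so losing the hydrogen-bond donor and acceptors of the leaving group does not by itself lower the number at this position. Within the data shown here, the large drop seen with compound 2 therefore belongs to that particular entering group and does not extend to every aryl group without a donor or acceptor: 4-bromophenyl in place of 4-fluoro-3-methylphenyl gives a 35-fold higher number from compound 2 to compound 4 (1.54 log units; beyond the scatter), and bromo in place of (oxiran-2-yl)methoxy on the aromatic carbon gives an 88-fold higher number from compound 3 to compound 4 (1.94 log units; beyond the scatter), so the substituents on this phenyl ring matter far more than the earlier steps could show. No measurement on hand accounts for these differences.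

As far as these compounds go, it remains open whether the low number of compound 3 depends on the oxirane ring or would persist with a simple propoxy chain. From the compounds shown here alone, the response of this position to an unsubstituted phenyl, a 4-chlorophenyl, or a phenyl carrying an aminomethyl group or a carboxylic acid also remains open.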